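The compounds below may be only part of what the source reports. "The series", "measured", "known", "first", "only" and "open" are said of these compounds alone.

Working notes on the shared core of compound 1 `N#CC1=C(N)Oc2c(c3nc4ccccc4nc3c3ccccc23)C12C(=O)N(Cc1cnnn1-c1ccccc1Cl)c1ccccc12`, here followed in an ADME assay on L02 cells (Homo sapiens) for antiproliferative activity, read by MTT assay, with a stated time of 48 h; on this read-out lower numbers stand for stronger inhibition and higher numbers for weaker inhibition. In this assay compound 1 gives only the limit of the assay, > 50000 nM. Compound 2 `CC(=O)Nc1ccc(-n2nncc2CN2C(=O)C3(C(C#N)=C(N)Oc4c3c3nc5ccccc5nc3c3ccccc43)c3ccccc32)cc1` carries 4-acetamidophenyl in place of 2-chlorophenyl on an aromatic nitrogen. In this assay compound 2 likewise gives only the limit, > 50000 nM. The step that the two limits leave unreadable from compound 1 to compound 2 is therefore of unreadable size, as both ends are limits. Compound 3 `Cc1ccccc1-n1nncc1CN1C(=O)C2(C(C#N)=C(N)Oc3c(N)cc4nc5ccccc5nc4c32)c2ccccc21` is the third member. In this assay compound 3 again gives only the limit, > 50000 nM. Compound 3 thus stands where every measured compound stands: at the limit of > 50000 nM in this assay, at which 3 of the 3 values shown sit, with no number beneath it.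

Compound 4 `CCc1cccc(C)c1-n1nncc1CN1C(=O)C2(C(C#N)=C(N)Oc3c(N)cc4nc5ccccc5nc4c32)c2ccccc21` differs from compound 3 by ethyl in place of hydrogen on an aromatic carbon, read one bond further out as 2-methylphenyl to 2-ethyl-6-methylphenyl. Going by the values given here, no measured step bears on this change; the single step in hand, from compound 1 to compound 2, cannot be read. Because the limit of > 50000 nM in this assay, at which 3 of the 3 values shown sit, holds for all three measured compounds, a change in reading for compound 4 is not expected. The expected step that the limit leaves unreadable from compound 3 to compound 4 is none beyond the scatter. Compound 4 is estimated at 60000 nM, with a range of 25000 nM to 150000 nM, most probably reported again as a limit.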

Compound 4, half-maximal inhibitory concentration: > 50000 nM
Compound 4 gave a limit, no number; the forecaster's own chance of this, stated with the estimate: 85%; the middle value lies beyond the limit too.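

No new step can be read in this assay: compound 3 and compound 4 both give only a limit, so the change from 2-methylphenyl to 2-ethyl-6-methylphenyl has no readable size. The compounds shown leave open what number any member of the series would give, and whether any change on the shared core shifts the reading: the limit of > 50000 nM in this assay, at which 4 of the 4 values shown sit.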